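Changing the group on the sulfonyl sulfur

A few compounds are considered here, and "the series" means these few. Any claim that something is new, unique, unknown or untested is made for them only; others in the source may bear on it.

Measured so far:
compound 1, `COc1cc2nc(N3CCN(S(=O)(=O)c4ccc(Cl)s4)CC3)nc(N)c2cc1OC`: 25000 nM
compound 2, `COc1ccc(S(=O)(=O)N2CCN(c3nc(N)c4cc(OC)c(OC)cc4n3)CC2)cc1`: 39000 nM

In a functional assay on PC-3 cells (Homo sapiens) for inhibition (on this read-out lower numbers stand for stronger inhibition and higher numbers for weaker inhibition), compound 2 gives the highest of the two numbers, with compound 1 nearest and within the scatter. Among the compounds with values here, the one measured step, a 1.6-fold higher number from compound 1 to compound 2 (0.19 log units; within the scatter), arose from exchanging the group on the sulfonyl sulfur, and it did not move the read-out beyond the scatter. Compound 3, `COc1cc2nc(N3CCN(S(=O)(=O)c4cc(Cl)ccc4Cl)CC3)nc(N)c2cc1OC`, makes a change of the same kind: 2,5-dichlorophenyl in place of 4-methoxyphenyl on a sulfonyl sulfur. Within the data shown here, with only that one step to go on, no movement beyond the scatter is expected in this assay, in either direction. Compound 3 is therefore estimated at 30000 nM, between 10000 nM and 90000 nM, which amounts to an expected 1.3-fold lower number from compound 2 to compound 3 (0.11 log units; within the scatter).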

Compound 3, half-maximal inhibitory concentration: 60000 nM
Compound 3: the middle estimate sits 2.0-fold (0.30 log units) below what was measured; low and high end bracket the measured number.
By their numbers in this assay, from the lowest: compounds 1, 2 and 3 (each within the scatter of the next, the first and the last beyond it).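

On the sulfonyl sulfur in this assay, 2,5-dichlorophenyl in place of 4-methoxyphenyl gives a 1.5-fold higher number from compound 2 to compound 3 (0.19 log units; within the scatter) and so stays within the scatter. In place of 5-chlorothiophen-2-yl, the same group gives a 2.4-fold higher number from compound 1 to compound 3 (0.38 log units; beyond the scatter), the only step shown that passes beyond the scatter, and a modest one. Nothing available accounts for this difference.

As far as these compounds go, whether a group other than an aromatic ring at this position, such as a longer alkyl chain, or a phenyl carrying an amine or a carboxylic acid, would lower the number in this assay remains open.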